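Swapping the phenol for a chloride on a cytotoxicity chalcone

A few compounds are considered here, and "the series" means these few. Any claim that something is new, unique, unknown or untested is made for them only; others in the source may bear on it.

Compound 3 `C=CCOc1cc(OC)c(C(=O)/C=C/c2ccc(O)cc2)c(OCC=C)c1` is one of three analogues sharing a core with two allyloxy groups and a methoxy group, differing only in the ring at the far end of the enone chain. In an ADME assay on Vero cells (Chlorocebus sabaeus) for cytotoxicity, read by MTT assay (a lower number here means a stronger inhibitor, a higher number a weaker inhibitor), compound 3 gives 76400 nM, the second highest of the three numbers. Compound 1 `C=CCOc1cc(OC)c(C(=O)/C=C/c2ccco2)c(OCC=C)c1` gives 191000 nM, and compound 2 `C=CCOc1cc(OC)c(C(=O)/C=C/c2ccc([N+](=O)[O-])cc2)c(OCC=C)c1` gives 12600 nM, the lowest. The steps are a 2.5-fold lower number from compound 1 to compound 3 (0.40 log units; beyond the scatter), a 15-fold lower number from compound 1 to compound 2 (1.18 log units; beyond the scatter) and a 6.1-fold higher number from compound 2 to compound 3 (0.78 log units; beyond the scatter).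

Compound 4 `C=CCOc1cc(OC)c(C(=O)/C=C/c2ccc(Cl)cc2)c(OCC=C)c1` has not yet been measured. Compared with compound 3 it differs in one place: chloro in place of hydroxy on an aromatic carbon. Among the compounds with values here, no measured step exchanges hydroxy for chloro, so the only guide is that the same position tolerates replacement, and that the nitro compound 2 gives a lower number than compound 3, as a 6.1-fold higher number from compound 2 to compound 3 (0.78 log units; beyond the scatter) shows. The change here is to a single atom without donor or acceptor, so I expect only a modest step in this assay, if any, toward a lower number, and the estimated step is a 1.9-fold lower number from compound 3 to compound 4 (0.28 log units; within the scatter). For compound 4 the expected value is 40000 nM, with a range from 15000 nM to 110000 nM.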

Compound 4, half-maximal inhibitory concentration: 10400 nM
Compound 4: middle estimate off by 3.8-fold (0.59 log units), on the high side, outside the stated range (below it).
By their numbers in this assay, from the lowest: compounds 4 and 2 (each within the scatter of the next); then compound 3; then compound 1.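

In this assay the exchange of hydroxy for chloro on this aromatic carbon, para to a large group, gives a clear step (a 7.3-fold lower number from compound 3 to compound 4 (0.87 log units; beyond the scatter)), so a change of one heavy atom for one heavy atom is enough to move the number well beyond the scatter. Chloro and nitro cannot be told apart here (a 1.2-fold lower number from compound 2 to compound 4 (0.08 log units; within the scatter)), which leaves hydroxy as the one group of the three phenyl substituents that stands apart, while the 4-chlorophenyl compound also lies far from the furan-2-yl compound (an 18-fold lower number from compound 1 to compound 4 (1.26 log units; beyond the scatter)). No supporting measurement is available to explain why hydroxy differs from chloro and nitro at this position.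

Only three substituents on this phenyl ring are shown, so it remains open whether an amine, a carboxylic acid or a methoxy group in the same place would fall with chloro and nitro or with hydroxy. Fluoro or bromo would test whether the result is particular to chloro, and a core without the two allyloxy groups would test whether these steps carry over at all.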